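This account rests on a few compounds, and the source may have more. Where it says the series, first, only, none or still open, it means among the compounds named here.

Working notes on the series. The compounds share a core, seen in compound 1 `O=C(/C=C1\CCc2cc(F)cc(F)c21)NC1CC1` and in compound 2 `CON(C)C(=O)/C=C1\CCc2ccc(F)cc21`. Among the measured compounds shown here, in a functional assay on the whole organism with Mus musculus as the target, at a dose of 100 mg/kg by the intraperitoneal route (a lower number here means less inhibition, a higher number more inhibition at the dose given (going by the name of the read-out)), compound 1 gives 100%, the higher of the two numbers measured so far. In this assay, for the measured compounds named here, compound 2 gives 17%, a number beyond the scatter below that of compound 1; compound 2 differs from compound 1 in more than one place, so the pair yields no single step and its two values are simply noted side by side.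

Compound 3 `CNC(=O)/C=C1\CCc2cc(F)cc(F)c21` is the next compound, differing from compound 1 by methyl in place of cyclopropyl on an amide-type nitrogen. Going by the values given here, no measured pair shows this change, so its size is open. The read-out for compound 1 already sits at the top of the scale, leaving room only for a drop or for no change beyond the scatter. Compound 3 is expected to remain well inhibited, with the step of a number 25 percentage points lower from compound 1 to compound 3 (beyond the scatter) estimated as a moderate loss that may just exceed the scatter. The estimate for compound 3 in this assay is 75%, with a range from 35% to 100%.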

Compound 3, a percentage reported as inhibition, in the whole organism at one dose (the size of the read-out at that dose, not a potency): 33%
For compound 3 the middle estimate is 42 percentage points above the measured one, outside the stated range (below it).
By their numbers in this assay, from the lowest: compound 2; then compound 3; then compound 1.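

Among the compounds shown here, the step of a number 67 percentage points lower from compound 1 to compound 3 (beyond the scatter) is the first single change the series offers, and it places methyl in place of cyclopropyl on an amide-type nitrogen with the rest of the core of compound 1 unchanged. For the compounds shown here, until now no pair isolated any one position, whereas this pair shows that the read-out at this dose depends strongly on the group at this nitrogen, and that cyclopropyl cannot be exchanged for methyl here without a large loss. Nothing at hand bears on why the read-out falls with this change.

Open, as far as these compounds go, is how the read-out behaves between these two groups and beyond them, for instance with ethyl, isopropyl or cyclobutyl on the same nitrogen, and whether the ring of the cyclopropyl matters or only the number of carbons, which a comparison of cyclopropyl with an open propyl chain would separate. Also open, from the compounds shown here alone, is whether any group here can match compound 1, and the single dose cannot rank such compounds once they reach the top of the scale, where compound 1 sits at 100%.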